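A few compounds are considered here, and "the series" means these few. Any claim that something is new, unique, unknown or untested is made for them only; others in the source may bear on it.

The measurements come from a functional assay on UO-31 cells (Homo sapiens) for inhibition, read by sulforhodamine B assay, with a stated time of 48 h; a lower number here means that less compound is tolerated, a higher number that more compound is tolerated. Compound 1 `Nc1cc(N)c2nc(-c3ccccc3)c(Oc3ccc(Cl)c(Cl)c3)nc2c1` carries a 3,4-dichlorophenoxy group on its core, and what this assay reports for it is only a limit of the assay, not a number: compound 1 gives < 100000 nM. Compound 2 `CCOC(=O)[C@H](CCC(=O)O)NC(=O)c1ccc(Sc2nc3cc(N)cc(N)c3nc2-c2ccccc2)cc1`, a thioether bearing a glutamate-derived amide, likewise reaches only a limit of the assay, giving < 100000 nM. Within the data shown here, compound 3 `COc1ccc(CNc2nc3cc(N)cc(N)c3nc2-c2ccccc2)cc1`, with a 4-methoxybenzylamino group in the same place, is the one member that returns a number, giving 72400 nM. Compound 1 therefore cannot be ranked against the others; it sits with compound 2 at the limit of < 100000 nM in this assay, at which 2 of the 3 values shown sit, while compound 3 lies just inside the measurable range.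

Compound 4 `Nc1cc(N)c2nc(-c3ccccc3)c(Sc3ccc(Cl)c(Cl)c3)nc2c1` has not yet been measured. It differs from compound 1 by (3,4-dichlorophenyl)sulfanyl in place of 3,4-dichlorophenoxy on an aromatic carbon. Among the measured compounds shown here, no measured pair shows what exchanging the oxygen linker for a sulfur linker does in this assay, so the expected step from compound 1 to compound 4 is taken as none beyond the usual scatter, a step that the limit leaves unreadable from compound 1 to compound 4. On that basis compound 4 is estimated at 70000 nM, with a plausible range from 25000 nM to 200000 nM, and it may well be reported again only as a limit.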

Compound 4, concentration lethal to 50% of the cells: < 100000 nM
Compound 4: only a limit was reported; the forecaster's own chance of this, stated with the estimate: 50%; the middle value is on the limit's open side.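

Compound 4, like compound 1, is reported only as a limit and not as a number, so no step can be read between them for (3,4-dichlorophenyl)sulfanyl in place of 3,4-dichlorophenoxy: the limit of < 100000 nM in this assay, at which 3 of the 4 values shown sit.

The compounds shown leave open what exchanging the oxygen linker for a sulfur linker does to the lethal concentration in this assay.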